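Aryl ketone exchange on a shared core: an expected third value

The source may hold more compounds than are shown below. What is called first, only, known or untested is meant among the compounds shown, and "the series" means these compounds.

compound 1, `COc1cc(-c2cc(/C=C/C(=O)c3ccc(Cl)c(Cl)c3)[nH]n2)cc(OC)c1OC`: -10%
compound 2, `COc1ccc(C(=O)/C=C/c2cc(-c3cc(OC)c(OC)c(OC)c3)n[nH]2)cc1`: -4%

In a functional assay on UACC-257 cells (Homo sapiens) for cytotoxicity, read by sulforhodamine B assay, with a stated time of 48 h, tested at 100 uM (a lower number here means a stronger effect, a higher number a weaker effect of the compound at the concentration tested), compound 1 gives -10%, and compound 2 gives -4%. Compound 2 stands highest of the two numbers, with compound 1 nearest. Among the compounds with values here, the one measured step is a number 6 percentage points higher from compound 1 to compound 2 (within the scatter). Compound 3, `COc1cc(-c2cc(/C=C/C(=O)c3ccc(F)c(F)c3)[nH]n2)cc(OC)c1OC`, is not yet measured; it carries 3,4-difluorophenyl in place of 4-methoxyphenyl on a carbonyl carbon. That earlier step, which put 4-methoxyphenyl in place of 3,4-dichlorophenyl on a carbonyl carbon, stayed within the scatter, so a similar exchange is expected to move little in this assay. Compound 3 is therefore expected to give -8%, between -30% and 14%. The expected step is a number 4 percentage points lower from compound 2 to compound 3 (within the scatter).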

Compound 3, a percentage reported as activity, at one concentration (the size of the read-out at that concentration, not a potency): -37%
The estimate for compound 3 lay 29 percentage points above the measured number; measured number outside the range, below it.
By their numbers in this assay, from the lowest: compound 3; then compounds 1 and 2 (each within the scatter of the next).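

In this assay, the group on the carbonyl carbon proved able to change the read-out: 3,4-difluorophenyl gives a number 33 percentage points lower from compound 2 to compound 3 (beyond the scatter) and a number 27 percentage points lower from compound 1 to compound 3 (beyond the scatter), a stronger effect at the concentration tested. The earlier exchange of 3,4-dichlorophenyl for 4-methoxyphenyl had shown no such separation, so this position is not indifferent to the aryl group it carries. The data offer no measured explanation for the difference between the two halogenated groups. On these data alone, it remains open whether both fluorines are needed and how a trifluoromethyl or nitrile group on that phenyl ring would read. A single concentration also shows only the stronger effect of compound 3 at that concentration and says nothing about other concentrations.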